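The source may hold more compounds than are shown below. What is called first, only, known or untested is meant among the compounds shown, and "the series" means these compounds.

Measured compounds:
- compound 1, `O=C(O)CCCCc1cccc(OCc2ccc3ccccc3n2)c1`: 100 nM
- compound 2, `O=C(O)C1CCC(c2ccc(OCc3ccc4ccccc4n3)cc2)C1`: 43 nM

Both were tested in an assay on membranes from lung (Cavia porcellus) for binding affinity to cysteinyl leukotriene receptor (Homo sapiens); on this read-out higher numbers stand for weaker inhibition and lower numbers for stronger inhibition. Compound 2 has the lower of the two numbers; compound 1 gives the higher one, and the gap between these two values lies beyond the usual scatter of repeated measurements. For the measured compounds named here, no single-point step between the two measured compounds can be drawn, as they differ in more than one place.

Compound 3, `O=C(O)CC1CCC(c2ccc(OCc3ccc4ccccc4n3)cc2)C1`, has not yet been measured in this assay. It differs from compound 2 in one place: carboxymethyl in place of carboxy on a saturated ring carbon. This adds one carbon between the five-membered ring and the acid group, a change of chain length rather than of the acid itself. Going by the values given here, with no measured pair to anchor such a lengthening, the expected step of a 1.2-fold higher number from compound 2 to compound 3 (0.07 log units; within the scatter) is small and could fall either way, within the scatter. Compound 3 is therefore expected to give about 50 nM, with a likely range from 15 nM to 170 nM.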

Compound 3, inhibition constant: 22 nM
The estimate for compound 3 lay 2.3-fold (0.36 log units) above the measured number, and the stated range covers the measured number.
By their numbers in this assay, from the lowest: compounds 3 and 2 (each within the scatter of the next); then compound 1.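

Swapping in carboxymethyl for carboxy on this saturated ring carbon gives a 2.0-fold lower number from compound 2 to compound 3 (0.29 log units; within the scatter) in this assay. For the compounds shown here, this is the first look at a one-carbon change at this position, and compound 2 and compound 3 cannot be told apart on this read-out, so the added carbon keeps the binding seen with the shorter group and neither group can be preferred. Nothing measured here offers an explanation for this result.

As far as these compounds go, it remains open whether a longer chain, such as carboxyethyl, would also hold this level in this assay. Also open, from the compounds shown here alone, is whether a different group at the same ring carbon, such as an amide or a tetrazole in place of the carboxylic acid, would keep it.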